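A few compounds are considered here, and "the series" means these few. Any claim that something is new, unique, unknown or untested is made for them only; others in the source may bear on it.

Compound 2 `CCOC(=O)C1=C(S[C@@H]2CN[C@H](C(=O)Nc3cccc(C(=O)OCC)c3)C2)[C@H](C)[C@@H]2[C@@H]([C@@H](C)O)C(=O)N12` is the reference here. In a physicochemical assay for metabolic stability, read by LC-MS, in phosphate buffer, with a stated time of 3 h, at pH 7.4, tested at 50 uM (on this read-out higher numbers stand for a more stable compound and lower numbers for a less stable compound), compound 2 gives > 95%, which is a limit of the assay rather than a number. Compound 3 `CCOC(=O)C1=C(S[C@@H]2CN[C@H](C(=O)Nc3cccc(C(=O)OCC)c3)C2)[C@H](C)[C@@H]2[C@@H]([C@@H](C)OC(=O)CC)C(=O)N12` differs from compound 2 by propanoyl in place of hydrogen on an oxygen on a saturated carbon. Within the data shown here, the only measured step, a step that the two limits leave unreadable from compound 1 to compound 2, touches the same oxygen. Compound 1 `CCOC(=O)C1=C(S[C@@H]2CN[C@H](C(=O)Nc3cccc(C(=O)OCC)c3)C2)[C@H](C)[C@@H]2[C@@H]([C@@H](C)OC(C)=O)C(=O)N12` gives > 95% in this assay, again a limit. Because (the limit of > 95% in this assay, at which 2 of the 2 values shown sit), no size can be read from that step. The step of a number no higher from compound 2 to compound 3 (the limit leaves the size open) is therefore expected to stay within the scatter. Compound 3 is expected at 95%, between 85% and 100%.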

Compound 3, percent of the compound remaining: > 95%
Compound 3 was reported as a limit (the forecaster's own chance of this, stated with the estimate: 75%); the middle value sits exactly at the limit.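

No step can be read among compound 1, compound 2 and compound 3, since all three sit at one limit rather than at a number: the limit of > 95% in this assay, at which 3 of the 3 values shown sit. The compounds shown leave open whether hydrogen, acetyl or propanoyl on that oxygen makes any difference in this assay.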